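The source may report more compounds than this note shows. Statements on the series, on what has been measured and on what is new or still open speak of the compounds shown alone.

In a functional assay on HGC-27 cells (Homo sapiens) for inhibition, read by MTT assay, with a stated time of 72 h (a higher number here means a weaker inhibitor, a lower number a stronger inhibitor), measured so far:
- compound 1 `C=C[C@]1(C)C[C@@H](OC(=O)CNC(=O)NC(=O)c2cccc(F)c2)[C@]2(C)[C@H](C)CC[C@]3(CCC(=O)[C@H]32)[C@@H](C)[C@@H]1O`: > 10000 nM, a limit
- compound 2 `C=C[C@]1(C)C[C@@H](OC(=O)CNC(=O)Nc2ccc(F)cc2F)[C@]2(C)[C@H](C)CC[C@]3(CCC(=O)[C@H]32)[C@@H](C)[C@@H]1O`: > 10000 nM, a limit

Compound 2 has no number in this assay, only the limit > 10000 nM. Compound 1 offers no number either, and the two compounds together make up (the limit of > 10000 nM in this assay, at which 2 of the 2 values shown sit).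

Compound 3 `C=C[C@]1(C)C[C@@H](OC(=O)CNC(=O)Nc2ccc(F)cc2)[C@]2(C)[C@H](C)CC[C@]3(CCC(=O)[C@H]32)[C@@H](C)[C@@H]1O` carries hydrogen in place of fluoro on an aromatic carbon, ortho to a large group and meta to a fluoro group, so that 2,4-difluorophenyl becomes 4-fluorophenyl: hydrogen in place of fluoro on an aromatic carbon.

For the measured compounds named here, the only measured step is a step that the two limits leave unreadable from compound 1 to compound 2. It is a different change and gives no size to carry over, so the series offers no measured guide to this replacement. The expectation rests on compound 2 alone, at its limit of > 10000 nM. No step beyond the scatter is expected in this assay, and a report of only a limit is the likeliest outcome.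

The estimated step is a step that the limit leaves unreadable from compound 2 to compound 3, reckoned from a limit. Compound 3 is estimated at 14000 nM, with an expected range of 6000 nM to 30000 nM.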

Compound 3, half-maximal inhibitory concentration: > 10000 nM
Compound 3 ended at the assay's limit; the forecaster's own chance of this, stated with the estimate: 80%; the middle value is on the limit's open side.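

The steps joining compound 1, compound 2 and compound 3 cannot be read, and no size can be given for any of them, as all three stand at one limit: the limit of > 10000 nM in this assay, at which 3 of the 3 values shown sit.

The compounds shown leave open how far each lies past that limit, and whether hydrogen in place of fluoro changes inhibition at all in this assay.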